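Aryl on the carbonyl: compound 1 to compound 3

A few compounds are considered here, and "the series" means these few. Any claim that something is new, unique, unknown or untested is made for them only; others in the source may bear on it.

Measured so far:
compound 1, `CCN1CCN(c2cc(C)c3cc(NC(=O)c4cc(Cl)cc(Cl)c4)ccc3n2)CC1`: 6090 nM in a functional assay on MCF7 cells (Homo sapiens) for antiproliferative activity, read by MTT assay, with a stated time of 72 h; a lower number here means a stronger inhibitor, a higher number a weaker inhibitor
compound 2, `Cc1cc(N2CCN(C)CC2)nc2ccc(NC(=O)c3ccc(Cl)c(Cl)c3)cc12`: 3000 nM in this assay

Of the two measured compounds, compound 1 carries the highest number in this assay; the nearest, compound 2, sits lower by a gap that is beyond the usual scatter, so compound 1 is the weaker of the pair here. Among the measured compounds shown here, no step between measured compounds that differ in one place is available.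

Compound 3, `CCN1CCN(c2cc(C)c3cc(NC(=O)c4ccc(OC)cc4)ccc3n2)CC1`, is not yet measured. It differs from compound 1 in one place: 4-methoxyphenyl in place of 3,5-dichlorophenyl on a carbonyl carbon. For the measured compounds named here, with no step to lean on, the direction of the change is open; the expectation is a modest movement, most likely none beyond the scatter, with a slight lean toward a higher number. Compound 3 is expected to give 8000 nM, within 2500 nM to 25000 nM, which is an estimated step of a 1.3-fold higher number from compound 1 to compound 3 (0.12 log units; within the scatter).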

Compound 3, half-maximal inhibitory concentration: 7690 nM
For compound 3 the middle estimate is 1.0-fold (0.02 log units) above the measured one; the range from low to high includes it.
By their numbers in this assay, from the lowest: compound 2; then compounds 1 and 3 (each within the scatter of the next).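

In this assay, the series now has its first step that changes one place only: 4-methoxyphenyl in place of 3,5-dichlorophenyl on a carbonyl carbon gives a 1.3-fold higher number from compound 1 to compound 3 (0.10 log units; within the scatter). For this pair, then, the aryl group on the carbonyl can lose its chlorine atoms and gain a methoxy group with no change that stands clear of the scatter, so this one exchange does not separate the two compounds. No measured information bearing on this result is available.

Going by these compounds, whether this position stays as unresponsive with a group other than a substituted phenyl on the carbonyl, such as a pyridine ring or a saturated alkyl chain, remains open. Also open, on these data alone, is whether a phenyl ring carrying an amine or a carboxylic acid would move the number beyond the scatter.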